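The source may hold more compounds than are shown below. What is called first, only, known or untested is meant among the compounds shown, and "the series" means these compounds.

Of the compounds shown here, two have been measured in a functional assay on HT-29 cells (Homo sapiens) for cytotoxicity, read by MTT assay, with a stated time of 72 h; a higher number here means a weaker inhibitor, a lower number a stronger inhibitor. Compound 1 `CN(C)CCCNc1nc(-c2ccc(NC(=O)Nc3ccc(Cl)cc3Cl)cc2)nc2c(Cl)c(Cl)sc12` gives 1320 nM in this assay, and compound 2 `CCN(CC)CCNc1nc(-c2ccc(NC(=O)Nc3ccccc3Cl)cc2)nc2c(Cl)c(Cl)sc12` gives 550 nM. Compound 2 therefore stands at the lower of the two numbers, and its gap to compound 1 lies beyond the usual scatter. Compounds 1 and 2 differ from each other in more than one part of the molecule, so their two values alone do not tell which part accounts for the gap.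

Compound 3 `CCN(CC)CCNc1nc(-c2ccc(NC(=O)Nc3ccc(Cl)cc3Cl)cc2)nc2c(Cl)c(Cl)sc12` is made from compound 2 by a single change: chloro in place of hydrogen on an aromatic carbon. Compound 1 already carries a (2,4-dichlorophenyl)carbamoyl group, but it also has a different side chain on the shared core, so its value cannot be read as the effect of the added chloro alone. Among the measured compounds shown here, no measured pair shows this change by itself. The step from compound 2 to compound 3 in this assay is therefore expected to be small, likely not beyond the scatter, with a slight lean toward a higher number given that compound 1 gives 1320 nM. Compound 3 is expected to give about 750 nM in this assay, within a range from 350 nM to 1600 nM, which means an expected step of a 1.4-fold higher number from compound 2 to compound 3 (0.13 log units; within the scatter).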

Compound 3, half-maximal inhibitory concentration: 1140 nM
Beside the measured number, compound 3's estimate is 1.5-fold (0.18 log units) below it; measured number inside the range.
By their numbers in this assay, from the lowest: compound 2; then compounds 3 and 1 (each within the scatter of the next).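

In this assay, chloro in place of hydrogen on this aromatic carbon, meta to a chloro group and para to a large group, gives a 2.1-fold higher number from compound 2 to compound 3 (0.32 log units; beyond the scatter) and so moves the reading toward a weaker inhibitor, although the step is only modest. With the 2,4-dichlorophenyl group held the same, diethylamino in place of (dimethylamino)methyl on the saturated chain gives a 1.2-fold lower number from compound 1 to compound 3 (0.06 log units; within the scatter) and so shows no difference that can be told from the scatter between the side chains of compound 1 and compound 3. No measurement shown here explains the effect of the added chloro on the number.

From the compounds shown here alone, whether this position responds to the chloro group in particular or would respond the same way to another group, such as fluoro, methoxy or an amine, remains open. Also open, going by these compounds, is whether removing the 2-chloro group while keeping the new chloro group would keep the number near that of compound 3, and whether the same step would appear with a longer chain on the nitrogen attached to the shared core.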